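The source may hold more compounds than are shown below. What is called first, only, known or untested is meant among the compounds shown, and "the series" means these compounds.

Measured compounds:
compound 1 `CCCCCCCCS(=O)(=O)Nc1cc(-c2ccc(Cl)cc2)ccc1C(=O)O` — 18100 nM
compound 2 `CCCCCCCCS(=O)(=O)Nc1cc(C(=O)c2ccc(CCCC)cc2)ccc1C(=O)O` — 15800 nM

In an assay on mitochondria (strain BALB/c) for inhibition of glycerol-3-phosphate acyltransferase 1, mitochondrial (Mus musculus), read by scintillation counting, with a stated time of 10 min (a higher number here means a weaker inhibitor, a lower number a stronger inhibitor), compound 1 gives 18100 nM, the top of the two numbers shown, and compound 2 gives 15800 nM, a gap that lies within the scatter, so neither compound can be called the weaker. Compound 3 `CCCCCCCCS(=O)(=O)Nc1cc(CCc2ccccc2)ccc1C(=O)O` differs from compound 1 in one place: phenethyl in place of 4-chlorophenyl on an aromatic carbon. For the measured compounds named here, no step between measured compounds is known, so nothing shows how such a change acts here. The expected step is a 1.1-fold lower number from compound 1 to compound 3 (0.05 log units; within the scatter), small and in no firm direction. Compound 3 is estimated at 16000 nM, with a range from 5000 nM to 50000 nM.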

Compound 3, half-maximal inhibitory concentration: 37500 nM
The estimate for compound 3 lay 2.3-fold (0.37 log units) below the measured number; low and high end bracket the measured number.
By their numbers in this assay, from the lowest: compounds 2 and 1 (each within the scatter of the next); then compound 3.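

At this position, on an aromatic carbon para to a carboxy group, the group carried does change the number in this assay: phenethyl in place of 4-chlorophenyl gives a 2.1-fold higher number from compound 1 to compound 3 (0.32 log units; beyond the scatter), a modest step toward weaker inhibition. For the compounds shown here, it is the only step that can be read here, and it shows that keeping a six-membered aromatic ring of carbon only at this place does not keep the number. Nothing at hand explains the step. From the compounds shown here alone, whether it follows the loss of chlorine or the added chain stays open. So does the effect of an unsubstituted phenyl or of an amine on that ring.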